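The source may report more compounds than this note shows. Statements on the series, on what has been measured and on what is new or still open speak of the compounds shown alone.

Measured in a functional assay for inhibition, with Homo sapiens as the target; on this read-out higher numbers stand for weaker inhibition and lower numbers for stronger inhibition:
compound 1 `CC(C)=C1CS(=O)(=O)c2cc(C(=O)N=C(N)N)c(C)cc21` gives 5030 nM
compound 2 `CCC1(O)CS(=O)(=O)c2cc(C(=O)N=C(N)N)c(C)cc21` gives 77 nM
compound 3 `Cc1cc2c(cc1C(=O)N=C(N)N)S(=O)(=O)CC2(O)C(=O)c1ccccc1` gives 157 nM

Compound 3, at 157 nM in this assay, has the second highest of the three numbers, much nearer to compound 2 than to compound 1. Compound 4 `Cc1cc2c(cc1C(=O)N=C(N)N)S(=O)(=O)CC2(C)O` is reached by one change, methyl in place of benzoyl on a saturated ring carbon. Going by the values given here, the one measured step at this place is a 2.0-fold higher number from compound 2 to compound 3 (0.31 log units; beyond the scatter), for benzoyl in place of ethyl. Methyl itself is untested, so this reversed step serves only as a guide, and a modest move toward a lower number is expected. The estimated step is a 1.7-fold lower number from compound 3 to compound 4 (0.22 log units; within the scatter), which may not clear the scatter. Compound 4 is expected at 95 nM, with an estimated range of 35 nM to 250 nM in this read-out.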

Compound 4, half-maximal inhibitory concentration: 115 nM
Compound 4: middle estimate off by 1.2-fold (0.08 log units), on the low side; low and high end bracket the measured number.
By their numbers in this assay, from the lowest: compounds 2, 4 and 3 (each within the scatter of the next, the first and the last beyond it); then compound 1.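

Replacing benzoyl with methyl on this saturated ring carbon gives a 1.4-fold lower number from compound 3 to compound 4 (0.14 log units; within the scatter), and removing one carbon from the ethyl group gives a 1.5-fold higher number from compound 2 to compound 4 (0.17 log units; within the scatter). Compound 4 therefore lies within the scatter of both neighbours, so methyl, the smallest group shown here, cannot be told apart from either ethyl or benzoyl at this position. No evidence is available to explain this.

Still open, going by these compounds, is whether an amine, a carboxylic acid or a longer chain at this carbon would stay within this range. The compounds also leave open whether the hydroxyl on the same carbon can be replaced by hydrogen.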